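Quinoxaline-type antifolate series: aryl-amino variations, working notes

The compounds below may be only part of what the source reports. "The series", "measured", "known", "first", "only" and "open" are said of these compounds alone.

Compound 1 `CN(Cc1nc2cc(C(F)(F)F)ccc2nc1-c1ccccc1)c1ccc(Cl)cc1` is measured in an assay on isolated protein for inhibition of Dihydrofolate reductase (Homo sapiens), read by spectrophotometry (a higher number here means a weaker inhibitor, a lower number a stronger inhibitor), where compound 1 gives 5000 nM. Compound 3 `COc1cc(N(C)Cc2nc3cc(C(F)(F)F)ccc3nc2-c2ccccc2)cc(OC)c1OC` gives 5000 nM, level with compound 1 at the digits printed, and together these are the highest of the three numbers. Compound 2 `COc1ccc(N(C)Cc2nc3cc(C(F)(F)F)ccc3nc2-c2ccccc2)cc1` gives 3000 nM; the step of a 1.7-fold lower number from compound 1 to compound 2 (0.22 log units; within the scatter) stays within the scatter. Compound 4 `CCN(Cc1nc2cc(C(F)(F)F)ccc2nc1-c1ccccc1)c1ccc(C)cc1` is not yet measured. It differs from compound 1 by ethyl(4-methylphenyl)amino in place of (4-chlorophenyl)(methyl)amino on a saturated chain carbon bound to an aromatic carbon. For the measured compounds named here, only the step from compound 1 to compound 2, a swap of the substituent on the same aromatic carbon, bears on this change, and it was within the scatter. No step beyond the scatter is therefore expected in this assay; the estimated step is no change at the digits printed from compound 1 to compound 4 (within the scatter). Compound 4 is expected near 5000 nM, within 2000 nM to 12000 nM.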

Compound 4, inhibition constant: 4000 nM
The estimate for compound 4 lay 1.3-fold (0.10 log units) above the measured number, and the stated range covers the measured number.
By their numbers in this assay, from the lowest: compounds 2, 4, 1 and 3 (each within the scatter of the next).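

In this assay, the ethyl(4-methylphenyl)amino group is not separated from either methylamino comparator: a 1.3-fold lower number from compound 1 to compound 4 (0.10 log units; within the scatter), and a 1.3-fold higher number from compound 2 to compound 4 (0.12 log units; within the scatter). Unlike the earlier compounds, which differ only in the ring substituent, compound 4 also carries ethyl in place of methyl on the amine nitrogen, and this combined change produces no step beyond the scatter. No measurement bears on why these values stay so close.

The separate contributions of the ethyl and the ring methyl remain unresolved. Also open, going by these compounds, is whether a longer chain such as butyl on that nitrogen, or a carboxylic acid on the ring, would produce a step beyond the scatter.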